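Oxygen-for-sulfur swap on an inactive sulfonyl scaffold

A few compounds are considered here, and "the series" means these few. Any claim that something is new, unique, unknown or untested is made for them only; others in the source may bear on it.

Compound 1 `O=S(=O)(CC1=NCCO1)C1C(c2ccc(Cl)cc2)=NOC1c1ccc(Cl)cc1` was examined in a functional assay, read by Griess assay, with a stated time of 150 min, tested at 100 ug/mL (a lower number here means a weaker effect, a higher number a stronger effect of the compound at the concentration tested), and gives "not active" (no number reported), with no number attached to it, so compound 1 stands without a measured value on this scale. Compound 2 `O=S(=O)(CC1=NCCO1)c1n[nH]cc1-c1ccccc1`, which shares the sulfonyl-linked chain, gives 57.5% in this assay. Among the measured compounds shown here, no two measured compounds differ in a single place, so no step size is fixed from the data at hand. Compound 3 `O=S(=O)(CC1=NCCS1)C1C(c2ccc(Cl)cc2)=NOC1c1ccc(Cl)cc1` has not yet been measured; it differs from compound 1 by a group of 5 heavy atoms (3 carbon, 1 nitrogen, 1 sulfur; one five-membered non-aromatic ring with 2 hetero atoms) in place of a group of 5 heavy atoms (3 carbon, 1 nitrogen, 1 oxygen; one five-membered non-aromatic ring with 2 hetero atoms), on a saturated chain carbon bound to a sulfonyl sulfur. With compound 1 lacking a number, the step cannot be computed; the change is small, and the expected step in this assay is none beyond the scatter, with no direction favored. Compound 3 is therefore estimated to give 10% in this assay, with a range from 0% to 30%.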

Compound 3, a percentage reported as activity, at one concentration (the size of the read-out at that concentration, not a potency): "not active" (no number reported)
Compound 3 has no reported number here, and the estimate cannot be compared.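

Among the compounds shown here, compound 1 and compound 3 both stand without a number in this assay, so no step between them can be read. On these data alone, whether their two five-membered rings differ in effect on this scale stays open, and no supporting evidence bears on the result.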